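Acetylating a sulfonamide nitrogen: expected effect on growth inhibition

A few compounds are considered here, and "the series" means these few. Any claim that something is new, unique, unknown or untested is made for them only; others in the source may bear on it.

compound 1, `COc1ccc(OC)c(-c2cc(-c3ccccc3)nn2-c2ccc(S(=O)(=O)NC(C)=O)cc2)c1`: 49800 nM
compound 2, `NS(=O)(=O)c1ccc(-n2nc(-c3ccccc3)cc2-c2cc(O)ccc2O)cc1`: 100000 nM

In a functional assay on cells (Cancer cell lines, Homo sapiens) for cytotoxicity, read by sulforhodamine B assay, with a stated time of 48 h (on this read-out higher numbers stand for weaker inhibition of growth and lower numbers for stronger inhibition of growth), compound 1 gives 49800 nM, and compound 2 gives 100000 nM. These two numbers lie within the usual scatter of each other, so compound 2 does not stand apart from compound 1 on this read-out. Compound 3 `CC(=O)NS(=O)(=O)c1ccc(-n2nc(-c3ccccc3)cc2-c2cc(O)ccc2O)cc1` has not yet been measured. It differs from compound 2 in one place: acetyl in place of hydrogen on a sulfonamide nitrogen. Within the data shown here, no measured pair shows this change alone; compound 1 carries the acetyl group but differs from compound 2 elsewhere too, so its value cannot be read as the effect of the acetyl by itself. With both measured numbers close together, the step to compound 3 is expected to stay within the scatter, in either direction. Compound 3 is therefore estimated at 70000 nM, with a range from 25000 nM to 150000 nM. The expected step is a 1.4-fold lower number from compound 2 to compound 3 (0.15 log units; within the scatter).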

Compound 3, concentration for total growth inhibition: 100000 nM
The estimate for compound 3 lay 1.4-fold (0.15 log units) below the measured number; low and high end bracket the measured number.
By their numbers in this assay, from the lowest: compounds 1, 2 and 3 (each within the scatter of the next).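

In this assay the acetyl group on the sulfonamide nitrogen can now be read by itself, and the step is no change at the digits printed from compound 2 to compound 3 (within the scatter) in this series. Among these compounds, the hydroxyl and methoxy forms of the aryl group can also be compared directly for the first time: 2,5-dihydroxyphenyl in place of 2,5-dimethoxyphenyl gives a 2.0-fold higher number from compound 1 to compound 3 (0.30 log units; within the scatter), so neither single change separates the compounds on this read-out. Nothing shown explains either result.

From the compounds shown here alone, it remains open whether a longer chain, such as a butanoyl group, or a benzoyl group on the same sulfonamide nitrogen would separate from hydrogen and acetyl. Going by these compounds, it is also open whether an amine or a carboxylic acid on the aromatic ring would separate from the 2,5-dihydroxyphenyl and 2,5-dimethoxyphenyl groups.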